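This account rests on a few compounds, and the source may have more. Where it says the series, first, only, none or still open, it means among the compounds named here.

Of the compounds shown here, three have so far been tested in a functional assay on A549 cells (Homo sapiens) for cytotoxicity, read by colorimetric assay and MTT assay; on this read-out lower numbers stand for stronger inhibition and higher numbers for weaker inhibition. Compound 1, `COc1cc(OC)c2cc(-c3ccc(OCc4ccccc4)cc3)c(O)nc2c1`, gives 10000 nM in this assay. Compound 2, `COc1ccc(-c2cc3c(OC)cc(OC)cc3n(CC(=O)OCc3ccccc3)c2=O)cc1`, gives 10000 nM in this assay, and compound 3, `COc1ccc(-c2cc3c(OC)cc(OC)cc3n(CC(=O)O)c2=O)cc1`, gives 10000 nM. Compound 2 and compound 3 differ in a single place, (hydrogen in place of benzyl on an oxygen next to a carbonyl group), and the step this change made, no change at the digits printed from compound 2 to compound 3 (within the scatter), leaves the half-maximal inhibitory concentration where it stood. Compound 1 is level with compound 2 and compound 3 at the digits reported, and its nearest neighbour on that reading is compound 2; how the core of compound 1 differs from the core of compound 2 is not broken down here.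

Compound 4, `COc1cc(OC)c2cc(-c3ccc(O)cc3)c(O)nc2c1`, has not yet been measured. It differs from compound 1 by the same kind of change, (hydrogen in place of benzyl on an oxygen on an aromatic ring). The place is not the same: in compound 2 the oxygen sits next to a carbonyl group whose other neighbours are carbonyl carbon, whereas in compound 1 the oxygen sits on an aromatic ring whose other neighbours are aromatic carbon, so the two changes are of the same kind rather than identical. The step from compound 1 to compound 4 in this assay is expected to be no change at the digits printed from compound 1 to compound 4 (within the scatter), because the earlier step of this kind made no difference no change at the digits printed from compound 2 to compound 3 (within the scatter) and all three measured compounds give one and the same reading. Compound 4 is therefore expected to give about 10000 nM in this assay, estimated to lie between 3000 nM and 30000 nM.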

Compound 4, half-maximal inhibitory concentration: 10000 nM
For compound 4 middle estimate and measured number coincide at the digits printed, and the stated range covers the measured number.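

In this assay, the loss of benzyl from an oxygen on an aromatic ring gives no change at the digits printed from compound 1 to compound 4 (within the scatter). Set beside the same kind of change on the other core, where the oxygen sits next to a carbonyl group, the two steps agree, so in this pair of cores the outcome carries over from one to the other: the same change on two cores in this assay, no change at the digits printed (within the scatter) from compound 2 to compound 3 and no change at the digits printed (within the scatter) from compound 1 to compound 4, 1.0-fold (0.00 log units) apart, within the scatter of two such steps This does not show that the change is without consequence in general, since only two cores are compared, the oxygen stands in a different place in each, and all four compounds give one and the same reading, so neither step tests the change on a compound that reads differently.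

The compounds shown leave open what other groups would do in place of benzyl on the oxygen of the core of compound 1, such as an amine-bearing side chain or a longer chain. They also leave open whether benzyl and hydrogen would still read alike on a core that gives a different reading in this assay.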